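Removing the Remaining Acetyl from Compound 2

A few compounds are considered here, and "the series" means these few. Any claim that something is new, unique, unknown or untested is made for them only; others in the source may bear on it.

Compound 1 `C=C1C(=O)O[C@]2(C)CC[C@@H]1C[C@H](O)[C@@]1(C)CC[C@H](OC(C)=O)[C@@](C)(CCC2=O)O1`: in a functional assay on HEp-2 cells (Homo sapiens) for cytotoxicity, read by MTT assay (on this read-out lower numbers stand for an effect already at smaller amounts and higher numbers for an effect only at larger amounts of compound), compound 1 gives < 20 ug/mL, a limit of the assay rather than a number.
Compound 2 `C=C1C(=O)O[C@]2(C)CC[C@@H]1C[C@H](O)[C@@]1(C)CC[C@H](O1)[C@](C)(O)CC[C@H]2OC(C)=O`: compound 2 gives < 20 ug/mL, likewise a limit.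
Compound 3 `C=C1C(=O)O[C@]2(C)CC[C@@H]1C[C@H](OC(C)=O)[C@@]1(C)CC[C@H](O1)[C@](C)(O)CC[C@H]2OC(C)=O`: compound 3 gives < 20 ug/mL, likewise a limit.

Compound 2 thus sits at the limit shared by every measured compound (the limit of < 20 ug/mL in this assay, at which 3 of the 3 values shown sit), so it cannot be ranked against compound 1 or compound 3. Compound 4 `C=C1C(=O)O[C@]2(C)CC[C@@H]1C[C@H](O)[C@@]1(C)CC[C@H](O1)[C@](C)(O)CC[C@H]2O` differs from compound 2 by hydrogen in place of acetyl on an oxygen on a saturated carbon. For the measured compounds named here, the one measured step involving an acetyl on such an oxygen, a step that the two limits leave unreadable from compound 2 to compound 3, has no readable size. Going by the values given here, no measured step therefore shows a direction for this change, and no shift beyond the scatter is expected. Compound 4 is estimated at 8 ug/mL, between 2 ug/mL and 20 ug/mL. That expected figure means a step that the limit leaves unreadable from compound 2 to compound 4, essentially none.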

Compound 4, concentration for half-maximal effect: < 20 ug/mL
Compound 4 was reported as a limit (the forecaster's own chance of this, stated with the estimate: 50%); the middle value lies beyond the limit too.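

No step can be read from compound 2 to compound 4, because both values are limits rather than numbers: the limit of < 20 ug/mL in this assay, at which 4 of the 4 values shown sit.

The size of the acetoxy to hydroxy change in this assay, and any ranking among these compounds, stays open.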